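Acyl-to-sulfonyl swap on the indole nitrogen of an IDE activator

This account rests on a few compounds, and the source may have more. Where it says the series, first, only, none or still open, it means among the compounds named here.

Compound 1 `O=C(CCCc1c[nH]c2ccccc12)NCCCn1ccnc1`: 10000 nM; 89100 nM (2 entries)
Compound 2 `O=C(CCCc1cn(C(=O)c2cccs2)c2ccccc12)NCCCn1ccnc1`: 21400 nM

In an assay on isolated protein for activation of Insulin-degrading enzyme (Homo sapiens), read by fluorescence, with stated times of 10 min and 20 min (a lower number here means that less compound is needed, a higher number that more compound is needed for the effect), compound 1 gives 10000 nM; 89100 nM (2 entries), and the spread of its repeated entries the several entries of compound 1 in this assay, 10000 nM; 89100 nM (2 entries) shows how loosely a single number in this assay can be trusted. Within the data shown here, compound 2, which carries a (thiophen-2-yl)carbonyl on the aromatic nitrogen of the shared core, gives 21400 nM in this assay; this is the only number for compound 2, and it lies within the span of the two entries of compound 1.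

Compound 3 `O=C(CCCc1cn(S(=O)(=O)c2ccc(F)cc2)c2ccccc12)NCCCn1ccnc1` has not yet been measured. It differs from compound 2 by (4-fluorophenyl)sulfonyl in place of (thiophen-2-yl)carbonyl on an aromatic nitrogen.

Among the measured compounds shown here, no measured pair shows what this kind of exchange does here, so the expectation rests only on compound 2 and its value 21400 nM. The step from compound 2 to compound 3 is expected to be a 1.1-fold lower number from compound 2 to compound 3 (0.03 log units; within the scatter), which is to say no change beyond the usual scatter in either direction. Compound 3 is therefore estimated to give 20000 nM in this assay, with a range from 5000 nM to 80000 nM.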

Compound 3, half-maximal effective concentration: 6760 nM
Compound 3: the middle estimate sits 3.0-fold (0.47 log units) above what was measured, within the range that was stated.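

The exchange of (thiophen-2-yl)carbonyl for (4-fluorophenyl)sulfonyl on the aromatic nitrogen gives a 3.2-fold lower number from compound 2 to compound 3 (0.50 log units; beyond the scatter) in this assay, so this position is not indifferent to what it carries, something that compound 2 alone could not show. Compound 3, at 6760 nM, also lies outside the span of the two entries of compound 1 on the side of less compound needed, whereas compound 2 lay inside that span. The step is only modest, however, and it rests on one value for each of the two compounds, so it should be read with caution in view of how far repeated entries can diverge: the several entries of compound 1 in this assay, 10000 nM; 89100 nM (2 entries)

The exchange alters two things at once, the carbonyl link to a sulfonyl link and the thiophene ring to a fluorinated benzene ring, and the compounds shown cannot tell which of the two accounts for the lower number. On these data alone, a (thiophen-2-yl)sulfonyl or a (4-fluorophenyl)carbonyl on the same nitrogen would separate the two, and it remains open whether the fluorine matters, which a plain phenylsulfonyl would address.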